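The source may report more compounds than this note shows. Statements on the series, on what has been measured and on what is new or still open speak of the compounds shown alone.

The study gathers three measured compounds and one yet to be measured. Compound 1 `O=c1[nH]cc(S(=O)(=O)Nc2ccccc2-c2cn(-c3ccccc3F)nn2)c(=O)[nH]1` gives 15300 nM in a functional assay on OVCAR-3 cells (Homo sapiens) for antiproliferative activity, read by MTT assay, with a stated time of 24 h; on this read-out lower numbers stand for stronger inhibition and higher numbers for weaker inhibition. Compound 2 `O=c1[nH]cc(S(=O)(=O)Nc2ccccc2-c2cn(-c3ccc(F)cc3)nn2)c(=O)[nH]1` in this assay reaches only the assay limit of > 20000 nM (the limit of > 20000 nM in this assay, at which 1 of the 3 values shown sits). The step of an at least 1.3-fold higher number from compound 1 to compound 2 (0.11 log units; that floor lies within the scatter) is therefore a floor rather than a measured difference. Compound 3 `Cc1ccc(-n2cc(-c3cccc(NS(=O)(=O)c4c[nH]c(=O)[nH]c4=O)c3)nn2)cc1` gives 3540 nM in this assay, the lowest of the two numbers shown, the nearest number being that of compound 1 at a gap that lies beyond the usual scatter.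

Compound 4 `O=c1[nH]cc(S(=O)(=O)Nc2cccc(-c3cn(-c4ccc(Cl)cc4)nn3)c2)c(=O)[nH]1` differs from compound 3 by a single change, (chloro in place of methyl on an aromatic carbon), chloro in place of methyl on an aromatic carbon, para to a large group; read one bond further out, 4-methylphenyl becomes 4-chlorophenyl. For the measured compounds named here, none of the measured steps touches this position or this exchange: the only measured step, that from compound 1 to compound 2, moves a fluoro substituent on a different ring and ends at a limit. No step beyond the scatter is therefore expected in this assay. The estimate for compound 4 is 3500 nM, between 1200 nM and 10000 nM, which means an expected step of a 1.0-fold lower number from compound 3 to compound 4 (0.00 log units; within the scatter).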

Compound 4, half-maximal inhibitory concentration: 2040 nM
Estimate against measurement, compound 4: 1.7-fold (0.23 log units) above, and the stated range covers the measured number.
By their numbers in this assay, from the lowest: compounds 4 and 3 (each within the scatter of the next); then compound 1. At a limit, above all of these: compound 2.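

In this assay, the exchange of 4-methylphenyl for 4-chlorophenyl gives a 1.7-fold lower number from compound 3 to compound 4 (0.24 log units; within the scatter), so on this read-out chloro and methyl cannot be told apart on an aromatic carbon para to a large group. For the compounds shown here, this is the first reading at this position, since the only earlier step moved a fluoro substituent on a different ring and ended at a limit, whereas this one joins two measured numbers and so gives a real size for the exchange, one that stays within the usual scatter. The compounds shown offer no measurement that accounts for the size of this step.

With only methyl and chloro shown at this position, it remains open whether a different group there, such as an amine, a carboxylic acid, a methoxy group or a longer chain, would give a step beyond the scatter. On these data alone, it is also open whether the same exchange of methyl for chloro would read alike on the core of compound 1, or in cells other than those of this assay.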